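Oxime group added to the fused core of compound 1

The compounds below may be only part of what the source reports. "The series", "measured", "known", "first", "only" and "open" are said of these compounds alone.

Going by the values given here, compound 1 `Cc1ccc2c(Cc3nn4cc(-c5ccc(Cl)cc5)nc4s3)coc2c1` stands at the top of the three numbers measured so far, yet its lead is small. In a functional assay on the whole organism (strain Wistar albino) for inhibition, with Rattus norvegicus as the target, read by paw edema, with a stated time of 0.5 h, at a dose of 100 mg/kg by the oral route (a lower number here means less inhibition, a higher number more inhibition at the dose given (going by the name of the read-out)), compound 1 gives 8.38%. Compound 2 `Cc1ccc2c(Cc3nn4cc(-c5ccc([N+](=O)[O-])cc5)nc4s3)coc2c1` gives 0% in this assay, and the change from compound 1 to compound 2, a number 8.4 percentage points lower from compound 1 to compound 2 (within the scatter), is within the scatter. Compound 3 `Cc1ccc2c(Cc3nn4c(CO)c(-c5ccc(Br)cc5)nc4s3)coc2c1` differs from compound 1 in two places. Compound 3 gives 2.38%, and the gap to compound 1 is also within the scatter.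

Compound 4 `Cc1ccc2c(Cc3nn4c(/C=N/O)c(-c5ccc(Cl)cc5)nc4s3)coc2c1` is not yet measured. It differs from compound 1 by a group of 3 heavy atoms (1 carbon, 1 nitrogen, 1 oxygen; no ring) in place of a hydrogen atom, on an aromatic carbon. Among the compounds with values here, no measured step touches this place on the core, so the only bearing comes from the general picture: every change so far has left the numbers low and within the scatter of each other, as the step from compound 1 to compound 2 shows with a number 8.4 percentage points lower from compound 1 to compound 2 (within the scatter). The expectation for compound 4 is therefore a step of a number 2.4 percentage points lower from compound 1 to compound 4 (within the scatter), no change beyond the scatter. Compound 4 is estimated at 6%, with a range from 0% to 18%.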

Compound 4, a percentage reported as inhibition, in the whole organism at one dose (the size of the read-out at that dose, not a potency): 6%
Beside the measured number, compound 4's estimate shows no gap at the digits printed; the measured number falls inside the stated range.
By their numbers in this assay, from the lowest: compounds 2, 3, 4 and 1 (each within the scatter of the next).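

The aromatic carbon next to the ring nitrogen and next to the ring atom that bears a 4-chlorophenyl group now has a reading for a single change: in this assay, the oxime group in place of hydrogen gives a number 2.4 percentage points lower from compound 1 to compound 4 (within the scatter). Going by these compounds alone, the earlier one-place step changed only the chloro group on an aromatic carbon elsewhere, so this is the first sign that this carbon can carry a group with a hydrogen-bond donor without a step beyond the scatter. No measured property or other outside data bears on this result.

On these data alone, whether a carboxylic acid or an amine on this carbon would move this assay beyond the scatter stays open. Also open, as far as these compounds go, is whether the oxime group would give a different reading with another aryl group on the neighbouring ring atom.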